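The compounds below may be only part of what the source reports. "The series", "measured", "known", "first", "only" and "open" are said of these compounds alone.

Measured in an ADME assay on isolated protein for pharmacokinetics, with UDP-glucuronosyltransferase 1A9 (Homo sapiens) as the target, read by LC-MS, with a stated time of 60 min, at 37 degrees C, tested at 1 uM, in the presence of a further agent that is not named here; on this read-out lower numbers stand for a shorter-lived compound and higher numbers for a longer-lived compound:
- compound 1 `NS(=O)(=O)CC(=O)NCCSc1nonc1/C(=N/O)Nc1ccc(F)c(Br)c1`: 0.758 h
- compound 2 `CS(=N)(=O)CC(=O)NCCSc1nonc1/C(=N/O)Nc1ccc(F)c(Br)c1`: 1.53 h
- compound 3 `NS(=O)(=O)NCCOc1nonc1/C(=N/O)Nc1ccc(F)c(Br)c1`: 0.0483 h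

Compound 3 sits at the bottom of the three numbers in this assay, with the nearest measured neighbour being compound 1, and compound 2 further away still; both gaps lie beyond the scatter. The unmeasured compound 4 `CS(=O)(=O)NCCSc1nonc1/C(=N/O)Nc1ccc(F)c(Br)c1` differs from compound 3 as follows: a group of 8 heavy atoms (3 carbon, 1 nitrogen, 2 oxygen, 2 sulfur; no ring) in place of a group of 8 heavy atoms (2 carbon, 2 nitrogen, 3 oxygen, 1 sulfur; no ring), on an aromatic carbon. The chain of compound 4 is thereby bound to the shared core through sulfur, as it is in compound 1 and compound 2, whereas in compound 3 it is bound through oxygen. Among the compounds with values here, no single-place step covers this change. Within the data shown here, the only step available, a 2.0-fold higher number from compound 1 to compound 2 (0.31 log units; beyond the scatter), concerns a swap on the chain of compound 1 and is modest; it says nothing direct about the change from compound 3 to compound 4. What the data show is that the two sulfur-bound compounds give far longer half-lives than compound 3, so the step of a 17-fold higher number from compound 3 to compound 4 (1.22 log units; beyond the scatter) is expected to be large and upward in this assay, landing compound 4 near compound 1. Compound 4 is therefore estimated at 0.8 h in this assay, with a range from 0.2 h to 2.5 h.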

Compound 4, half-life: 0.357 h
Compound 4: the middle estimate sits 2.2-fold (0.35 log units) above what was measured, within the range that was stated.
By their numbers in this assay, from the lowest: compound 3; then compound 4; then compound 1; then compound 2.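

In this assay the exchange on the aromatic carbon, where the 2-(sulfamoylamino)ethoxy chain leaves, gives a 7.4-fold higher number from compound 3 to compound 4 (0.87 log units; beyond the scatter) and shows that this position moves the half-life, yet the step joins two changes: the atom binding the chain to the shared core and the end of the chain. The group on the amine nitrogen also counts with the sulfur link held constant: methylsulfonyl in place of (sulfamoylmethyl)carbonyl gives a 2.1-fold lower number from compound 1 to compound 4 (0.33 log units; beyond the scatter) in this series, and the same nitrogen also shows a 4.3-fold lower number from compound 2 to compound 4 (0.63 log units; beyond the scatter) within the sulfur-bound set, so the sulfur link alone does not set the half-life. Nothing at hand accounts for any of these steps.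

The compounds shown do not separate the linking atom from the end group, and an oxygen-bound chain ending in methylsulfonyl would be the matching partner for that question. As far as these compounds go, how a carboxylic acid, an amine or a longer chain in place of the methylsulfonyl group would read in this assay also stays open.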